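This account rests on a few compounds, and the source may have more. Where it says the series, first, only, none or still open, it means among the compounds named here.

Measured compounds:
- Compound 1, `CC(C)(C)C#Cc1cc(N(C(=O)[C@H]2CC[C@H](C)CC2)[C@H]2CC[C@H](OC3CCOC3)CC2)c(C(=O)O)s1`: 3070 nM
- Compound 2, `CC(C)(C)C#Cc1cc(N(C(=O)[C@H]2CC[C@H](C)CC2)[C@H]2CC[C@](O)(CO[C@H]3CCOC3)CC2)c(C(=O)O)s1`: 8980 nM

These values come from an ADME assay on MT4 cells (Homo sapiens) for cytotoxicity, with a stated time of 5 days; a lower number here means that less compound is tolerated, a higher number that more compound is tolerated. Of the two numbers, compound 1 stands lowest, and compound 2 sits higher by a gap that lies beyond the usual scatter. Compound 3, `CC(C)(C)C#Cc1cc(N(C(=O)[C@H]2CC[C@H](C)CC2)[C@H]2CC[C@H](Oc3ccncn3)CC2)c(C(=O)O)s1`, has not yet been measured in this assay. It differs from compound 1 in one place: pyrimidin-4-yl in place of oxolan-3-yl on an oxygen on a saturated carbon. Within the data shown here, no measured pair tells what such a change does here. For compound 3 the step of a 1.1-fold higher number from compound 1 to compound 3 (0.06 log units; within the scatter) is expected to stay within the scatter, in no firm direction. Compound 3 is therefore estimated at 3500 nM, between 1200 nM and 10000 nM.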

Compound 3, half-maximal cytotoxic concentration: 599 nM
Beside the measured number, compound 3's estimate is 5.8-fold (0.77 log units) above it; measured number below the stated range.
By their numbers in this assay, from the lowest: compound 3; then compound 1; then compound 2.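

In this assay, the group on this oxygen clearly matters: pyrimidin-4-yl in place of oxolan-3-yl gives a 5.1-fold lower number from compound 1 to compound 3 (0.71 log units; beyond the scatter) and so less compound is tolerated. Among these compounds, this is the first single-place change, and it shows that swapping the group on an oxygen on a saturated carbon can move the number beyond the scatter. No measurement here explains the step. From the compounds shown here alone, whether the step follows the aromatic ring or its two ring nitrogens stays open. A phenyl ring on the same oxygen would help separate the two.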